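From hydroxy to methoxy: compound 2 and compound 3

The compounds below may be only part of what the source reports. "The series", "measured", "known", "first", "only" and "open" are said of these compounds alone.

- Compound 1 `C#Cc1cccc(Nc2ncnc3cc(NC(=O)/C=C/c4ccccc4)sc23)c1`: 20500 nM
- Compound 2 `O=C(/C=C/c1ccc(O)cc1)Nc1cc2c(Nc3ccc(Cl)c(Cl)c3)ncnc2s1`: 24800 nM

In a functional assay on HeLa cells (Homo sapiens) for antiproliferative activity, read by MTT assay, with a stated time of 48 h (a higher number here means a weaker inhibitor, a lower number a stronger inhibitor), compound 2 gives 24800 nM, which lies within the scatter of compound 1 at 20500 nM. Compound 3 `COc1ccc(/C=C/C(=O)Nc2cc3c(Nc4ccc(Cl)c(Cl)c4)ncnc3s2)cc1` differs from compound 2 by methyl in place of hydrogen on an oxygen on an aromatic ring, turning 4-hydroxyphenyl into 4-methoxyphenyl. Among the compounds with values here, no measured step bears on this change, so no step beyond the scatter is expected in this assay, in either direction. The estimated 1.2-fold lower number from compound 2 to compound 3 (0.09 log units; within the scatter) is expected to stay within the scatter. For compound 3 the expected value is 20000 nM, with an estimated range of 8000 nM to 50000 nM.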

Compound 3, half-maximal inhibitory concentration: 33 nM
Beside the measured number, compound 3's estimate is 610-fold (2.78 log units) above it, outside the stated range (below it).
By their numbers in this assay, from the lowest: compound 3; then compounds 1 and 2 (each within the scatter of the next).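

In this assay, the oxygen on the aromatic ring turns out to be a highly sensitive place: methyl in place of hydrogen there gives a 750-fold lower number from compound 2 to compound 3 (2.88 log units; beyond the scatter) in a single change. This is the first step shown between compounds that differ in one place, and it involves only one added heavy atom. Nothing measured here accounts for its size. From the compounds shown here alone, it remains open whether ethoxy, a longer chain, or an amine at this place would retain the low number seen with methoxy. Also open, going by these compounds, is whether the same change would have a similar effect with other groups elsewhere on the molecule.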